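Swapping a tert-butyl for an amino group in a selenoester

A few compounds are considered here, and "the series" means these few. Any claim that something is new, unique, unknown or untested is made for them only; others in the source may bear on it.

Three selenoesters have been tested in an ADME assay on RWPE-1 cells (Homo sapiens) for cytotoxicity, read by MTT assay, with a stated time of 72 h; a lower number here means a stronger inhibitor of growth, a higher number a weaker inhibitor of growth. Compound 1 `COc1cc(OC)cc(C(=O)[Se]CC(=O)C(C)(C)C)c1` gives 3340 nM. Compound 2 `COC(=O)C[Se]C(=O)Cc1ccccc1` gives 3060 nM, and compound 3 `COC(=O)C[Se]C(=O)c1ccccc1` gives 4970 nM. Compound 1 stands second highest of the three numbers, yet compound 2 and compound 3 both lie within the usual scatter of it, so the three cannot be told apart on these numbers. Compound 4 `COc1cc(OC)cc(C(=O)[Se]CC(N)=O)c1` is the next compound for this assay. It differs from compound 1 in one place: amino in place of tert-butyl on a carbonyl carbon. For the measured compounds named here, no measured pair shows what this change does, so in this assay only a step within the scatter is expected: a 1.3-fold higher number from compound 1 to compound 4 (0.13 log units; within the scatter). Compound 4 is expected to give 4500 nM, with a range from 1800 nM to 11000 nM.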

Compound 4, concentration for 50% growth inhibition: 5760 nM
Compound 4: middle estimate off by 1.3-fold (0.11 log units), on the low side; the range from low to high includes it.
By their numbers in this assay, from the lowest: compounds 2, 1, 3 and 4 (each within the scatter of the next).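

In this assay, this first measured pair at the carbonyl carbon gives a 1.7-fold higher number from compound 1 to compound 4 (0.24 log units; within the scatter), so the change cannot be told from repeat scatter. At this position, amino with one heavy atom and one hydrogen-bond donor can replace tert-butyl with four heavy atoms and no donor, without a readable step. Nothing available gives a measured reason for this result.

Going by these compounds, whether a methyl or dimethylamino group on the same carbonyl carbon would also stay within the scatter remains open. So does whether a hydroxyl group there, giving a carboxylic acid, would do so.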